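This account rests on a few compounds, and the source may have more. Where it says the series, first, only, none or still open, it means among the compounds named here.

In a functional assay on CHO cells for activation of adenosine receptor A2b (Homo sapiens), read by cAMP accumulation (on this read-out lower numbers stand for an effect already at smaller amounts and higher numbers for an effect only at larger amounts of compound), compound 3, with the structure `CCNC(=O)[C@H]1O[C@@H](n2cnc3c(NNC(=O)c4ccccc4)nc(Cl)nc32)[C@H](O)[C@@H]1O`, does not give a number but only the assay limit of > 5000 nM. Compound 1, with the structure `CCNC(=O)[C@H]1O[C@@H](n2cnc3c(NNC(=O)c4ccccc4)ncnc32)[C@H](O)[C@@H]1O`, likewise stops at the limit of > 5000 nM, again a limit rather than a measured value. the limit of > 5000 nM in this assay, at which 2 of the 3 values shown sit, marks where both of these stand. Going by the values given here, compound 2, with the structure `CCNC(=O)[C@H]1O[C@@H](n2cnc3c(NNC(=O)c4ccc(C)o4)ncnc32)[C@H](O)[C@@H]1O`, is the only one with a readable number in this assay and gives 227 nM.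

Of the measured steps, an at least 22-fold lower number from compound 1 to compound 2 (1.34 log units; beyond the scatter) is the one that can be sized; the other, a step that the two limits leave unreadable from compound 1 to compound 3, cannot be read since both of its ends are limits. Compound 4, with the structure `CCNC(=O)[C@H]1O[C@@H](n2cnc3c(NNC(=O)c4sccc4C)nc(Cl)nc32)[C@H](O)[C@@H]1O`, carries the change (3-methylthiophen-2-yl in place of phenyl on a carbonyl carbon). This closely resembles the swap behind the large improvement seen going from compound 1 to compound 2, where a methyl-bearing five-membered aromatic ring also took the place of the phenyl on the carbonyl carbon. A step in the same direction is therefore expected for compound 4, although the chloro present on compound 3 has no readable precedent of its own. The expected step is an at least 10-fold lower number from compound 3 to compound 4 (1.00 log units; beyond the scatter). Compound 4 is estimated at 500 nM, with a likely range from 100 nM to 3000 nM.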

Compound 4, half-maximal effective concentration: 340 nM
Beside the measured number, compound 4's estimate is 1.5-fold (0.17 log units) above it; the range from low to high includes it.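

In this assay, replacing phenyl with 3-methylthiophen-2-yl on the carbonyl carbon gives an at least 14-fold lower number from compound 3 to compound 4 (1.16 log units; beyond the scatter), so a readable effect appears even with chloro on the shared core. Until now, such a gain at this position had been seen only without chloro and only with 5-methylfuran-2-yl, so the gain now holds for two different five-membered aromatic rings, one with oxygen and one with sulfur, each carrying a methyl, and on two versions of the core. The real size of the new step stays unknown, and the printed figure is only a minimum, because compound 3 gives a limit of the assay rather than a number: the limit of > 5000 nM in this assay, at which 2 of the 4 values shown sit.

What chloro itself contributes remains unclear, since the step that adds it to the phenyl compound cannot be read, with both of its ends being limits. Also open is how much the methyl matters: the compounds shown do not tell how a plain thiophen-2-yl, or a ring carrying an amine or a carboxylic acid in place of the methyl, would read on this carbonyl carbon.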